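The compounds below may be only part of what the source reports. "The series", "measured", "known", "first", "only" and "open" are said of these compounds alone.

Measured in a functional assay on SK-BR-3 cells (Homo sapiens) for antiproliferative activity, read by MTT assay, with a stated time of 72 h; on this read-out higher numbers stand for weaker inhibition and lower numbers for stronger inhibition:
- compound 1 `C=CC(=O)Nc1cc2c(Nc3ccc(OCc4cccc(F)c4)c(Cl)c3)ncnc2cc1OCc1cn(CCCC(=O)NO)nn1`: 20200 nM
- compound 2 `CN(C)C/C=C/C(=O)Nc1cc2ncnc(Nc3ccc(F)c(Cl)c3)c2cc1O[C@@H]1CCOC1`: 5560 nM

Compound 1 carries the higher of the two numbers in this assay, so it is the weaker inhibitor here, and the gap to compound 2 lies beyond the scatter. The next compound is compound 3 `C=CC(=O)Nc1cc2c(Nc3ccc(OCc4cccc(F)c4)c(Cl)c3)ncnc2cc1OCc1cn(CCC(=O)NO)nn1`, which keeps the core of compound 1 and changes only the chain end: hydroxycarbamoyl in place of (hydroxycarbamoyl)methyl on a saturated chain carbon, two bonds along the chain from an aromatic nitrogen. Hydroxycarbamoyl takes the place of (hydroxycarbamoyl)methyl on a saturated chain carbon, two bonds along the chain from an aromatic nitrogen, so 3-(hydroxycarbamoyl)propyl becomes 2-(hydroxycarbamoyl)ethyl. Among the compounds with values here, no measured pair isolates this change, so the expectation starts from compound 1 at 20200 nM. No step beyond the scatter is expected, and the estimated change is a 1.3-fold lower number from compound 1 to compound 3 (0.13 log units; within the scatter). For compound 3 the expected value is 15000 nM, with an estimated range of 6000 nM to 40000 nM.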

Compound 3, half-maximal inhibitory concentration: 24800 nM
Compound 3: middle estimate off by 1.7-fold (0.22 log units), on the low side; low and high end bracket the measured number.
By their numbers in this assay, from the lowest: compound 2; then compounds 1 and 3 (each within the scatter of the next).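

In this assay, 2-(hydroxycarbamoyl)ethyl in place of 3-(hydroxycarbamoyl)propyl gives a 1.2-fold higher number from compound 1 to compound 3 (0.09 log units; within the scatter), so this assay does not separate the two chains. Within the data shown here, this is the first pair that differs in one place, and it shows that the chain end, on a saturated chain carbon, two bonds along the chain from an aromatic nitrogen, can be altered in this way without a step beyond the scatter. Nothing at hand bears on this result.

Still open, as far as these compounds go, is whether a longer chain than 3-(hydroxycarbamoyl)propyl, or a shorter one such as (hydroxycarbamoyl)methyl on the same ring, would shift the number in this assay. Also open, from the compounds shown here alone, is whether a carboxylic acid or a primary amide at the chain end, in place of hydroxycarbamoyl, would read any differently.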